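The source may hold more compounds than are shown below. What is called first, only, known or untested is meant among the compounds shown, and "the series" means these compounds.

Compound 1 (`COc1cc2c(cc1OC)C(=O)C(C(=O)Nc1ccc(Br)cc1)C2`) gives 72.1 ug/mL
Compound 2 (`CCc1cccc(NC(=O)C2Cc3cc(OC)c(OC)cc3C2=O)c1`) gives 64.1 ug/mL
Compound 3 (`COc1cc2c(cc1OC)C(=O)C(C(=O)Nc1cccc(Cl)c1)C2`) gives 76.3 ug/mL

In a physicochemical assay, with a stated time of 30 min (a higher number here means a weaker inhibitor, a lower number a stronger inhibitor), compound 3 gives 76.3 ug/mL and lies within the scatter of the other two compounds, with a 1.1-fold higher number from compound 1 to compound 3 (0.02 log units; within the scatter) and a 1.2-fold higher number from compound 2 to compound 3 (0.08 log units; within the scatter) as the measured steps. Compound 4 (`COc1ccccc1NC(=O)C1Cc2cc(OC)c(OC)cc2C1=O`) has not yet been measured. It carries 2-methoxyphenyl in place of 3-chlorophenyl on an amide-type nitrogen. The nearest evidence is the change of group on that nitrogen, which gave a 1.1-fold lower number from compound 1 to compound 2 (0.05 log units; within the scatter) and a 1.1-fold higher number from compound 1 to compound 3 (0.02 log units; within the scatter) and stayed within the scatter both times. Among the measured compounds shown here, no measured compound carries 2-methoxyphenyl, so the evidence is thin. No step beyond the scatter is therefore expected, and the estimate is a 1.1-fold lower number from compound 3 to compound 4 (0.04 log units; within the scatter) in this assay terms. For compound 4 the estimated value is 70 ug/mL with an expected range from 42 ug/mL to 115 ug/mL here.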

Compound 4, half-maximal inhibitory concentration: 45.8 ug/mL
Estimate against measurement, compound 4: 1.5-fold (0.18 log units) above; the measured number falls inside the stated range.
By their numbers in this assay, from the lowest: compounds 4, 2, 1 and 3 (each within the scatter of the next).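

Among the compounds shown here, with 2-methoxyphenyl on the amide-type nitrogen, the first group in this set to carry a hydrogen-bond acceptor, every new step in this assay stays within the scatter (a 1.7-fold lower number from compound 3 to compound 4 (0.22 log units; within the scatter)) (a 1.4-fold lower number from compound 2 to compound 4 (0.15 log units; within the scatter)) (a 1.6-fold lower number from compound 1 to compound 4 (0.20 log units; within the scatter)). This position has therefore now taken bromo-, chloro-, ethyl- and methoxy-bearing phenyl groups without any step beyond the scatter. Nothing available bears on the reason for this result. On these data alone, whether an amine or a carboxylic acid on that phenyl ring would give a step beyond the scatter remains open. So does the effect of replacing the phenyl ring with a longer alkyl chain.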